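The source may hold more compounds than are shown below. What is called first, only, known or untested is meant among the compounds shown, and "the series" means these compounds.

Measured in a functional assay on A549 cells (Homo sapiens) for antiproliferative activity, read by MTT assay, with a stated time of 48 h; a higher number here means a weaker inhibitor, a lower number a stronger inhibitor:
- Compound 1 `O=C(/C=C/c1ccc(O)c(O)c1)N1CCN(c2ccc(F)cc2)CC1`: 1.25 ug/mL
- Compound 2 `O=C(/C=C/c1ccc(O)c(O)c1)N1CCN(c2ccc([N+](=O)[O-])cc2)CC1`: 1.56 ug/mL

In this assay, compound 2 lies within the scatter of compound 1, so neither ranks ahead. Compound 3 `CCN1CCN(C(=O)/C=C/c2ccc(O)c(O)c2)CC1` carries ethyl in place of 4-nitrophenyl on an amine nitrogen in a ring. Among the compounds with values here, the only measured step, a 1.2-fold higher number from compound 1 to compound 2 (0.10 log units; within the scatter), swaps a group on the aromatic ring but keeps that ring, so it offers little guidance, and no measured compound lacks the ring. A modest rise in the number is expected, with wide uncertainty. The estimated change is a 1.9-fold higher number from compound 2 to compound 3 (0.28 log units; within the scatter). Compound 3 is expected at 3 ug/mL, within an estimated range of 1 ug/mL to 10 ug/mL.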

Compound 3, half-maximal inhibitory concentration: 6.54 ug/mL
Estimate against measurement, compound 3: 2.2-fold (0.34 log units) below, and the stated range covers the measured number.
By their numbers in this assay, from the lowest: compounds 1 and 2 (each within the scatter of the next); then compound 3.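

In this assay, within the data shown here, replacing the aromatic ring on the ring nitrogen with ethyl gives the first change here that lies beyond the scatter, with a modest weakening whether the group lost is 4-nitrophenyl (a 4.2-fold higher number from compound 2 to compound 3 (0.62 log units; beyond the scatter)) or 4-fluorophenyl (a 5.2-fold higher number from compound 1 to compound 3 (0.72 log units; beyond the scatter)). So removing the whole substituted ring at this position matters more than the one swap of a group on that ring. Nothing available explains the loss.

Going by these compounds, whether the aromatic ring itself counts, or only the size of the group, stays open. A cyclohexyl ring or a longer chain such as hexyl on the same nitrogen would separate the two.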